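Swapping an Acetyl for a Dimethylamino Group

This account rests on a few compounds, and the source may have more. Where it says the series, first, only, none or still open, it means among the compounds named here.

Of the compounds shown here, two share a core and have been tested for their effect on prostate cancer cells. Compound 1 `COc1cc(C)cc(-c2c(-c3ccnc(-c4ccc(C(C)=O)cc4)c3)cnn2CC#N)c1` gives 24% in a functional assay on PC-3 cells (Homo sapiens) for cytotoxicity, read by sulforhodamine B assay, with a stated time of 48 h, tested at 1 uM; a lower number here means a stronger effect, a higher number a weaker effect of the compound at the concentration tested. Compound 2 `COc1cc(C)cc(-c2nn(CC#N)cc2-c2ccc(-c3cccc(C(C)=O)c3)nc2)c1` gives 20% in this assay, and the two numbers lie within the usual scatter of each other, so neither can be called the stronger of the pair.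

Compound 3 `COc1cc(C)cc(-c2c(-c3ccnc(-c4ccc(N(C)C)cc4)c3)cnn2CC#N)c1` has not yet been measured. It differs from compound 1 in one place: dimethylamino in place of acetyl on an aromatic carbon. Within the data shown here, no measured pair in this set shows what such a change does, so there is no basis for expecting a step in either direction. The step expected from this change is a number 4 percentage points higher from compound 1 to compound 3 (within the scatter), which is none beyond the scatter. Compound 3 is therefore estimated at 28% in this assay, with a range from 10% to 60% that reflects how little is known.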

Compound 3, a percentage reported as activity, at one concentration (the size of the read-out at that concentration, not a potency): 13%
Compound 3: middle estimate off by 15 percentage points, on the high side; the measured number falls inside the stated range.
By their numbers in this assay, from the lowest: compounds 3, 2 and 1 (each within the scatter of the next, the first and the last beyond it).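

Placing 4-(dimethylamino)phenyl where compound 1 has 4-acetylphenyl gives a number 11 percentage points lower from compound 1 to compound 3 (beyond the scatter) in this assay, so this position is not indifferent to the group it carries, and the change strengthens the effect at the tested concentration. The two groups match in heavy-atom count, hydrogen-bond donors and acceptors, and neither carries a net charge, so these counts do not separate them. Nothing measured on these compounds accounts for the step.

A single swap cannot show which feature of the dimethylamino group matters, and a plain amino group or a morpholine ring at the same place would give a wider view of this position. As far as these compounds go, whether the same swap would have a similar effect on compound 2 also remains open.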